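The source may report more compounds than this note shows. Statements on the series, on what has been measured and on what is new or still open speak of the compounds shown alone.

Working notes on the series. In a functional assay on MCF7 cells (Homo sapiens) for cytotoxicity, read by MTT assay, with a stated time of 72 h (on this read-out higher numbers stand for weaker inhibition and lower numbers for stronger inhibition), compound 1 (`Cc1cc(=O)n(-c2ccccc2OC(F)(F)F)nc1C(=O)Nc1ccc(Oc2ncnc3c2ccn3C)c(F)c1`) gives > 60000 nM, a limit of the assay and not a number. Compound 2 (`Cc1cc(=O)n(-c2ccc(Br)cc2F)nc1C(=O)Nc1ccc(Oc2ncnc3c2ccn3C)c(F)c1`) gives > 60000 nM, likewise only a limit. Both compounds therefore stand at the limit of > 60000 nM in this assay, at which 2 of the 2 values shown sit. Among the measured compounds shown here, the only measured step is a step that the two limits leave unreadable from compound 1 to compound 2, and it offers neither a size nor a direction to carry forward.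

The next compound is compound 3 (`Cc1cc(=O)n(-c2ccccc2Cl)nc1C(=O)Nc1ccc(Oc2ncnc3c2ccn3C)c(F)c1`), which carries 2-chlorophenyl in place of 4-bromo-2-fluorophenyl on an aromatic nitrogen. For the measured compounds named here, with only the step that the two limits leave unreadable from compound 1 to compound 2 to go on, no change beyond the scatter is expected in this assay, in either direction. The expected step is a number no higher from compound 2 to compound 3 (the limit leaves the size open). Another report of a limit is the likeliest outcome. For compound 3 the estimate is 60000 nM, with an expected range from 25000 nM to 120000 nM.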

Compound 3, half-maximal inhibitory concentration: > 60000 nM
Compound 3: a limit, no number; the forecaster's own chance of this, stated with the estimate: 80%; the middle value lies on the limit itself.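

The steps among compound 1, compound 2 and compound 3 cannot be read, as each gives a limit of the assay and not a number: the limit of > 60000 nM in this assay, at which 3 of the 3 values shown sit.

The compounds shown leave open whether the groups on the aromatic nitrogen differ at all in cytotoxicity.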